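Dimethylamino to diethylamino amide change on the methoxy core

The compounds below may be only part of what the source reports. "The series", "measured", "known", "first", "only" and "open" are said of these compounds alone.

Compound 1 `CC(/C=C/CC(C)CCCC(C)C)=C\C(=O)N(C)C` gives 4.94 in a physicochemical assay for lipophilicity; on this read-out higher numbers stand for higher lipophilicity and lower numbers for lower lipophilicity. Compound 2 `CCN(CC)C(=O)/C=C(C)/C=C/CC(C)CCCC(C)C` carries diethylamino in place of dimethylamino on a carbonyl carbon and gives 6.02 in this assay; the step is a number 1.08 log units higher from compound 1 to compound 2 (beyond the scatter). Compound 3 `COC(C)(C)CCCC(C)C/C=C/C(C)=C/C(=O)N(C)C` differs from compound 1 in its core by methoxy in place of hydrogen on a saturated chain carbon bound to three saturated chain carbons; in this assay compound 3 gives 3.74, and the step is a number 1.20 log units lower from compound 1 to compound 3 (beyond the scatter). Among the three measured values, that of compound 3 is the lowest, with compound 1 nearest and compound 2 furthest.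

Compound 4 `CCN(CC)C(=O)/C=C(C)/C=C/CC(C)CCCC(C)(C)OC` is not yet measured. It differs from compound 3 by diethylamino in place of dimethylamino on a carbonyl carbon, the same change as from compound 1 to compound 2; the place is described in the same words for both pairs, a carbonyl carbon whose other neighbour is a double-bonded chain carbon, so the change is taken as the same change on a different core.

Compound 4 is expected to give 4.82 in this assay, between 4.35 and 5.3. The estimated step of a number 1.08 log units higher from compound 3 to compound 4 (beyond the scatter) is set beside the earlier step of a number 1.08 log units higher from compound 1 to compound 2 (beyond the scatter). For the measured compounds named here, this rests on compound 3 giving 3.74 and on the single prior instance of the change; with only one such pair measured, the range is kept somewhat open.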

Compound 4, partition coefficient: 4.82
Estimate against measurement, compound 4: no gap at the digits printed; the measured number falls inside the stated range.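

In this assay the change from dimethylamino to diethylamino on a carbonyl carbon gives a number 1.08 log units higher from compound 3 to compound 4 (beyond the scatter) on the methoxy core, the same size as a number 1.08 log units higher from compound 1 to compound 2 (beyond the scatter) on the core of compound 1, and the methoxy change likewise gives a number 1.20 log units lower from compound 2 to compound 4 (beyond the scatter), the same size as a number 1.20 log units lower from compound 1 to compound 3 (beyond the scatter). The four compounds thus form a closed square in which each change carries over between these two cores without a gap at the digits printed, but this rests on two pairs per change and one read-out, and sets no rule for any other core or for the series as a whole. Nothing available here accounts for the agreement between the steps.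

From the compounds shown here alone, whether the same step holds for a longer amide substituent such as dipropylamino on a carbonyl carbon remains open. So does whether it survives on a core carrying hydroxy or a carboxylic acid in place of the methoxy group.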